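Swapping trifluoromethoxy for phenyl in a hydroxamic acid series

A few compounds are considered here, and "the series" means these few. Any claim that something is new, unique, unknown or untested is made for them only; others in the source may bear on it.

Compound 1 `O=C(NO)c1cnc(N2C[C@@H]3[C@H](C2)[C@H]3NCc2ccc(C(F)(F)F)cc2)nc1` gives 700 nM in a functional assay on HCT-116 cells (Homo sapiens) for antiproliferative activity, read by WST assay, with a stated time of 72 h; a lower number here means a stronger inhibitor of growth, a higher number a weaker inhibitor of growth
Compound 2 `O=C(NO)c1cnc(N2C[C@@H]3[C@H](C2)[C@H]3NCc2ccc(OC(F)(F)F)cc2)nc1` gives 120 nM in this assay

Going by the values given here, of these two numbers, the one for compound 2 is the lower, and the gap between them lies beyond the scatter. The next compound to be tested is compound 3 `O=C(NO)c1cnc(N2C[C@@H]3[C@H](C2)[C@H]3NCc2ccc(-c3ccccc3)cc2)nc1`, which carries phenyl in place of trifluoromethoxy on an aromatic carbon, para to a large group (see (phenyl in place of trifluoromethoxy on an aromatic carbon)). Among the compounds with values here, only one measured step bears on this change. That step, a 5.8-fold lower number from compound 1 to compound 2 (0.77 log units; beyond the scatter), is modest and exchanged trifluoromethyl for trifluoromethoxy on an aromatic carbon. It shows that a change of group at this carbon can move the number beyond the scatter. However, no measured compound carries a ring there, so the data do not fix a direction for phenyl. A step of no greater size than that one is expected, perhaps leaning slightly towards a higher number. The expected change is a 1.7-fold higher number from compound 2 to compound 3 (0.22 log units; within the scatter). In this assay, compound 3 is estimated at 200 nM, with an expected range of 60 nM to 650 nM.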

Compound 3, concentration for 50% growth inhibition: 56 nM
Compound 3: the middle estimate sits 3.6-fold (0.55 log units) above what was measured; the measured number lies below the stated range.
By their numbers in this assay, from the lowest: compound 3; then compound 2; then compound 1.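

In this assay, going by these compounds alone, the step from trifluoromethoxy to phenyl gives a 2.1-fold lower number from compound 2 to compound 3 (0.33 log units; beyond the scatter), so this aromatic carbon accepts a six-membered aromatic ring of carbon only, and the earlier compounds, neither of which has a ring there, could not show this. The wider comparison, with a 13-fold lower number from compound 1 to compound 3 (1.10 log units; beyond the scatter), shows that the choice of group at this one carbon can move the number by a large step while the rest of the molecule stays the same. Among these three compounds, the lowest number belongs to compound 3, the only one with no fluorine in this group, although three compounds cannot establish a general pattern, and nothing measured here explains either step.

On these data alone, it remains open whether the number would keep falling with a pyridine ring in place of phenyl, or with a phenyl ring that itself carries an amine or a carboxylic acid. A small group such as methyl is also untested in this set, so the compounds shown do not tell whether the ring itself matters or whether other groups at this carbon would do as well.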